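The compounds below may be only part of what the source reports. "The series", "measured", "known", "first", "only" and "open" are said of these compounds alone.

Measured compounds in an assay on CHO cells for inhibition of sodium- and chloride-dependent glycine transporter 1 (Homo sapiens), read by scintillation counting; on this read-out higher numbers stand for an effect only at larger amounts of compound and lower numbers for an effect already at smaller amounts:
compound 1 `C[C@H](Oc1ccc(S(C)(=O)=O)cc1C(=O)N1Cc2cc(C(F)(F)F)cnc2C1)C(F)(F)F` gives 50 nM;
compound 2 `C[C@H](Oc1ccc(S(C)(=O)=O)cc1C(=O)N1Cc2ccc(C3CCCCO3)cc2C1)C(F)(F)F` gives 205 nM;
compound 3 `CC(C)Oc1ccc(S(C)(=O)=O)cc1C(=O)N1Cc2cc(C(F)(F)F)cnc2C1` gives 70 nM.

Compound 3 stands second highest of the three numbers, close to compound 1 and further from compound 2, which sits beyond the scatter above it. Going by the values given here, the only measured step at the same place, a 1.4-fold higher number from compound 1 to compound 3 (0.15 log units; within the scatter), lies within the scatter, so exchanging the group on the oxygen on the aromatic ring has so far changed little. The change to compound 4 `CC(C)COc1ccc(S(C)(=O)=O)cc1C(=O)N1Cc2cc(C(F)(F)F)cnc2C1` is isobutyl in place of isopropyl on an oxygen on an aromatic ring. On that evidence the step of a 1.3-fold higher number from compound 3 to compound 4 (0.11 log units; within the scatter) in this assay is expected to be small, with no direction beyond the scatter. Compound 4 is therefore estimated at 90 nM, within 40 nM to 200 nM.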

Compound 4, half-maximal effective concentration: 30 nM
The estimate for compound 4 lay 3.0-fold (0.48 log units) above the measured number, outside the stated range (below it).
By their numbers in this assay, from the lowest: compounds 4, 1 and 3 (each within the scatter of the next, the first and the last beyond it); then compound 2.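

In this assay, going by these compounds alone, the group on the oxygen on an aromatic ring now shows an effect: isobutyl in place of isopropyl gives a 2.3-fold lower number from compound 3 to compound 4 (0.37 log units; beyond the scatter), the first step at this place beyond the scatter. Isobutyl in place of 1-(trifluoromethyl)ethyl gives a 1.7-fold lower number from compound 1 to compound 4 (0.22 log units; within the scatter), which stays within the scatter, so compound 1 and compound 4 cannot be told apart. Nothing at hand bears on why the step from isopropyl to isobutyl has this size. Going by these compounds, it remains open whether a longer chain, such as pentyl, or a cyclopropylmethyl group on this oxygen would extend the step. On these data alone, it also remains open whether isobutyl would give a similar step on the core of compound 2.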